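This account rests on a few compounds, and the source may have more. Where it says the series, first, only, none or still open, it means among the compounds named here.

Going by the values given here, compound 1 `Cc1cc(NNC(=O)Nc2cc(Cl)nc(Cl)c2)ncc1N(C)C` is one of two compounds measured in a functional assay on CHO cells for antagonist activity at sphingosine 1-phosphate receptor 2 (Homo sapiens), read by scintillation counting and GTPgammaS binding, with a stated time of 4 h, in the presence of a further agent that is not named here; a lower number here means a stronger inhibitor, a higher number a weaker inhibitor. In this assay compound 1 gives 5.3 nM, the lowest of the two numbers, while compound 2 `Cc1cc(CO)nc(NNC(=O)Nc2cc(Cl)nc(Cl)c2)c1` gives 31 nM in this assay, a higher number that lies beyond the scatter. Compound 3 `Cc1cc(NNC(=O)Nc2cc(Cl)nc(Cl)c2)ncc1-c1cnn(C)c1` has not yet been measured. It differs from compound 1 by 1-methyl-1H-pyrazol-4-yl in place of dimethylamino on an aromatic carbon, in words 1-methyl-1H-pyrazol-4-yl in place of dimethylamino on an aromatic carbon. Among the compounds with values here, no measured pair shows this exchange, so nothing in the numbers tells how large the step should be or which way it runs. The account therefore expects only a small step, most likely a slight loss, a 2.3-fold higher number from compound 1 to compound 3 (0.35 log units; beyond the scatter), one that may well stay within the scatter. For compound 3 the estimated value in this assay is 12 nM, expected to fall between 3 nM and 50 nM.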

Compound 3, half-maximal inhibitory concentration: 3.4 nM
Compound 3: the middle estimate sits 3.5-fold (0.55 log units) above what was measured; the measured number falls inside the stated range.
By their numbers in this assay, from the lowest: compounds 3 and 1 (each within the scatter of the next); then compound 2.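

The exchange at this position, on an aromatic carbon ortho to a methyl group and two atoms from the ring nitrogen, gives a 1.6-fold lower number from compound 1 to compound 3 (0.19 log units; within the scatter) in this assay, so the two compounds cannot be told apart in this read-out. The position therefore accepts a 1-methyl-1H-pyrazol-4-yl group, with its five-membered aromatic ring, as well as it accepts the open-chain dimethylamino group, and the low nanomolar level of compound 1 does not depend on dimethylamino being there. No measurement offers a reason why the two groups fare alike.

One exchange cannot show how far this tolerance extends, for instance to a carboxylic acid, a morpholine or a longer alkyl chain at the same carbon. As far as these compounds go, whether the neighbouring methyl group contributes anything also remains open.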